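The compounds below may be only part of what the source reports. "The series", "measured", "known", "first", "only" and "open" are said of these compounds alone.

In a functional assay on A549 cells (Homo sapiens) for antiproliferative activity, read by sulforhodamine B assay, with a stated time of 48 h (a higher number here means a weaker inhibitor of growth, a lower number a stronger inhibitor of growth), three compounds have been measured so far. Compound 1 (`COc1ccc(Nc2nc(NCCCO)c3ccccc3n2)cc1`) gives 15200 nM. Compound 2 (`Nc1ccc(Nc2nc(NC3CCCC3)c3ccccc3n2)cc1`) gives 15900 nM. Compound 3 (`N#Cc1ccc(Nc2nc(NCCCO)c3ccccc3n2)cc1`) gives 3000 nM, the lowest number of the three, which makes it the strongest growth inhibitor among them.

The next structure, compound 4 (`Nc1ccc(Nc2nc(NCCCO)c3ccccc3n2)cc1`), has amino in place of cyano on an aromatic carbon, para to a large group: amino in place of cyano on an aromatic carbon. Among the compounds with values here, one measured step touches the same position: a 5.1-fold lower number from compound 1 to compound 3 (0.70 log units; beyond the scatter), a modest change beyond the scatter, seen when cyano replaced methoxy. Compound 3 therefore owes its place to a compound that differs only in this group. Compound 2 also carries the 4-aminophenyl group, although with a different group elsewhere on the core, and it gives 15900 nM. Within the data shown here, no amino compound sharing the chain of compound 3 has been measured yet.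

A move back towards weaker inhibition, of about the size of the measured step, is expected. The estimated change is a 3.7-fold higher number from compound 3 to compound 4 (0.56 log units; beyond the scatter). For compound 4 the estimated value is 11000 nM, with an expected range of 4500 nM to 25000 nM.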

Compound 4, concentration for 50% growth inhibition: 17100 nM
For compound 4 the middle estimate is 1.6-fold (0.19 log units) below the measured one; low and high end bracket the measured number.
By their numbers in this assay, from the lowest: compound 3; then compounds 1, 2 and 4 (each within the scatter of the next).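

In this assay, the change from 4-cyanophenyl to 4-aminophenyl gives a 5.7-fold higher number from compound 3 to compound 4 (0.76 log units; beyond the scatter) and so undoes the advantage of the nitrile, while a 1.1-fold higher number from compound 1 to compound 4 (0.05 log units; within the scatter) lies within the scatter, which means amino and methoxy cannot be told apart and, of the three groups seen at this place, only cyano stands out. With amino in this place, a 1.1-fold higher number from compound 2 to compound 4 (0.03 log units; within the scatter) also lies within the scatter, so 3-hydroxypropyl and cyclopentyl on the nitrogen cannot be told apart in this pair. Nothing available explains why cyano stands apart from the other two groups.

On these data alone, it remains open whether cyano is unique at this place or whether another group, such as a carboxylic acid or a chlorine atom, would give a similarly low number. As far as these compounds go, it is also open whether cyclopentyl and 3-hydroxypropyl would still match each other with cyano on the ring instead of amino.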